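A few compounds are considered here, and "the series" means these few. Any claim that something is new, unique, unknown or untested is made for them only; others in the source may bear on it.

Working notes on the series. Among the compounds with values here, compound 3 `Cc1ccc(S(=O)(=O)N(C)c2ccc3[nH]c(-c4n[nH]c5ccccc45)cc3n2)cc1` gives 16300 nM in a functional assay on SMMC-7721 cells (Homo sapiens) for antiproliferative activity, read by MTT assay, with a stated time of 72 h; a lower number here means a stronger inhibitor, a higher number a weaker inhibitor; this is the lowest of the three numbers so far. Compound 2 `COc1cccc(C(=O)N(C)c2ccc3[nH]c(-c4n[nH]c5ccccc45)cc3n2)c1` gives 22000 nM, and the step of a 1.3-fold lower number from compound 2 to compound 3 (0.13 log units; within the scatter) is within the scatter. Compound 1 `CCC(=O)N(C)c1ccc2[nH]c(-c3n[nH]c4ccccc34)cc2n1` gives 33500 nM; the step of a 2.1-fold lower number from compound 1 to compound 3 (0.31 log units; beyond the scatter) is the only one beyond the scatter, and a 1.5-fold lower number from compound 1 to compound 2 (0.18 log units; within the scatter) is within it.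

Compound 4 `CN(c1ccc2[nH]c(-c3n[nH]c4ccccc34)cc2n1)S(=O)(=O)c1ccc(OC(F)(F)F)cc1` carries the change (trifluoromethoxy in place of methyl on an aromatic carbon). Within the data shown here, none of the measured steps alters a substituent on the sulfonyl aryl ring; all three concern the group on the ring nitrogen, and those moved this assay only modestly. A step of no more than modest size is therefore expected, direction unknown: a 1.2-fold lower number from compound 3 to compound 4 (0.07 log units; within the scatter). The expected value for compound 4 is 14000 nM, with a range of 5500 nM to 36000 nM.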

Compound 4, half-maximal inhibitory concentration: 7160 nM
For compound 4 the middle estimate is 2.0-fold (0.29 log units) above the measured one; measured number inside the range.
By their numbers in this assay, from the lowest: compound 4; then compounds 3, 2 and 1 (each within the scatter of the next, the first and the last beyond it).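

In this assay, going from 4-methylphenyl to 4-(trifluoromethoxy)phenyl gives a 2.3-fold lower number from compound 3 to compound 4 (0.36 log units; beyond the scatter). Within the data shown here, this is the first step at this aromatic carbon, and it shows that the sulfonyl aryl ring can move the number beyond the scatter, though only modestly. Nothing available explains this step.

With only methyl and trifluoromethoxy shown at this carbon, it remains open whether the step extends to other groups there, such as a methoxy group, a chlorine atom or an amine. From the compounds shown here alone, the effect of the same change on the amide compounds also remains open.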